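Replacing the sulfamoylphenyl group of compound 1

The source may hold more compounds than are shown below. What is called first, only, known or untested is meant among the compounds shown, and "the series" means these compounds.

In a functional assay on MDA-MB-231 cells (Homo sapiens) for inhibition, read by MTT assay, with a stated time of 48 h (a higher number here means a weaker inhibitor of growth, a lower number a stronger inhibitor of growth), compound 1 `NS(=O)(=O)c1ccc(NC(=S)Nc2ccc3ncnc(Nc4cccc(Br)c4)c3c2)cc1` gives > 30000 nM, which is a limit and not a number. Compound 2 `O=S(=O)(Nc1nccs1)c1ccc(NC(=S)Nc2ccc3ncnc(Nc4cccc(Br)c4)c3c2)cc1`, which also carries a sulfonamide, gives > 30000 nM, again a limit. That leaves a step that the two limits leave unreadable from compound 1 to compound 2, so this pair offers no size to build on. Compound 3 `FC(F)(F)c1cc(NC(=S)Nc2ccc3ncnc(Nc4cccc(Br)c4)c3c2)cc(C(F)(F)F)c1`, which has no sulfonamide, gives a true number, 800 nM. Compound 4 `S=C(Nc1ccc(Cl)c(Cl)c1)Nc1ccc2ncnc(Nc3cccc(Br)c3)c2c1` differs from compound 1 in one place: 3,4-dichlorophenyl in place of 4-sulfamoylphenyl on an amide-type nitrogen. It also lacks the sulfonamide, so, going by compound 3 at 800 nM, a measurable value is expected. The expected change is an at least 20-fold lower number from compound 1 to compound 4 (1.30 log units; beyond the scatter), towards stronger growth inhibition. For compound 4 the estimated value is 1500 nM, with an expected range of 500 nM to 6000 nM.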

Compound 4, concentration for 50% growth inhibition: 4800 nM
Compound 4: middle estimate off by 3.2-fold (0.51 log units), on the low side, and the stated range covers the measured number.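

In this assay, the step at this amide-type nitrogen can now be read: replacing 4-sulfamoylphenyl with 3,4-dichlorophenyl gives an at least 6.2-fold lower number from compound 1 to compound 4 (0.79 log units; beyond the scatter). Swapping one sulfonamide-bearing group for another gave no readable step, whereas this swap removes the sulfonamide and shows stronger growth inhibition. The full size of the step remains unknown because compound 1 has only a limit: the limit of > 30000 nM in this assay, at which 2 of the 4 values shown sit.

The compounds shown leave open whether the sulfonamide itself or the chlorines drive this change. A plain phenyl, or a phenyl carrying a carboxylic acid or an amine, could help separate these possibilities.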